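Replacing pyridin-4-yl with tert-butoxycarbonyl on compound 2

A few compounds are considered here, and "the series" means these few. Any claim that something is new, unique, unknown or untested is made for them only; others in the source may bear on it.

Compound 1 `CC(Oc1nn(-c2ccccc2F)c2ccc(F)cc12)C(=O)N1CCOCC1` - 717 mL/min/kg
Compound 2 `O=C1N(c2ccncc2)CCN1c1cccc2c1cnn2-c1ccccc1F` - 228 mL/min/kg

Both numbers come from an ADME assay on liver for metabolic stability, with Liver microsome (Rattus norvegicus) as the target, using microsomes and NADPH, with a stated time of 30 min, tested at 0.5 uM (a higher number here means faster removal of the compound, a lower number slower removal), and only these two are available so far. Compound 2 at 228 mL/min/kg stands lowest of the two, and the gap to compound 1 at 717 mL/min/kg lies beyond the scatter.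

Compound 3 `CC(C)(C)OC(=O)N1CCN(c2cccc3c2cnn3-c2ccccc2F)C1=O` has not yet been measured. It keeps the core of compound 2 and differs in one place tert-butoxycarbonyl in place of pyridin-4-yl on an amide-type nitrogen in a ring. Going by the values given here, no measured pair shows this kind of change, so the expectation rests on thin evidence. Among the compounds with values here, compound 2 already sits at the lower end of the known numbers, and the only higher reference is compound 1 at 717 mL/min/kg (a compound with a different structure). The expectation therefore leans upward, with a moderate rise that stays within the scatter. The expected change is a 1.8-fold higher number from compound 2 to compound 3 (0.24 log units; within the scatter) (an estimate with wide uncertainty). For compound 3 the estimated clearance is 400 mL/min/kg (expected range 170 mL/min/kg to 850 mL/min/kg).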

Compound 3, clearance: 120 mL/min/kg
Compound 3: middle estimate off by 3.3-fold (0.52 log units), on the high side; measured number outside the range, below it.
By their numbers in this assay, from the lowest: compounds 3 and 2 (each within the scatter of the next); then compound 1.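

In this assay, going by these compounds alone, exchanging pyridin-4-yl for tert-butoxycarbonyl on the amide-type nitrogen of the five-membered non-aromatic ring gives a 1.9-fold lower number from compound 2 to compound 3 (0.28 log units; within the scatter), the first reading of any change at this position. The two numbers therefore cannot be told apart, even though a six-membered aromatic ring with one hetero atom gives way to a group with no ring, and the ring nitrogen of the pyridin-4-yl group is lost while two oxygen atoms enter. At this position, then, clearance does not depend on that aromatic ring being present, at least for this one exchange on this core, and nothing shown here accounts for how close the two numbers lie.

On these data alone, it remains open whether a plain phenyl ring, a short alkyl chain such as methyl, or a chain ending in an amine or a carboxylic acid on the same nitrogen would also lie within the scatter of these two compounds. A single step also leaves open whether the same exchange would read alike on a different core.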